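The source may hold more compounds than are shown below. What is called first, only, known or untested is meant among the compounds shown, and "the series" means these compounds.

Compound 1 `CCCOC(=O)C1=C(C)NC(=O)NC1c1ccoc1` gives 50% in an assay on membranes from CHO cells for displacement of a labelled ligand from adenosine receptor A1 (Homo sapiens), read by scintillation counting, with a stated time of 60 min, tested at 1 uM; on this read-out lower numbers stand for less inhibition and higher numbers for more inhibition at the one concentration tested (going by the name of the read-out). Compound 2 `CCCOC(=O)C1=C(C)NC(=O)NC1c1cccs1` gives 43%. Compound 3 `CCCOC(=O)C1=C(C)N(C)C(=O)NC1c1ccoc1` gives 1%.

Compound 1 stands highest of the three numbers. The step of a number 7 percentage points lower from compound 1 to compound 2 (within the scatter) stays within the scatter, whereas the step of a number 49 percentage points lower from compound 1 to compound 3 (beyond the scatter) is large and well beyond it. Compound 4 `CCNC(=O)C1=C(C)NC(=O)NC1c1ccoc1` has not been measured; it differs from compound 1 by ethylamino in place of propoxy on a carbonyl carbon. Going by the values given here, neither measured step touches the carbonyl carbon, so no step speaks directly to this change; the two steps only show that the number in this assay stays level after one alteration and is lower after another. A moderate fall is expected, with wide uncertainty, so compound 4 is estimated at 35%, between 10% and 65%, that is an expected step of a number 15 percentage points lower from compound 1 to compound 4 (beyond the scatter).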

Compound 4, a percentage reported as inhibition, at one concentration (the size of the read-out at that concentration, not a potency): 1%
The estimate for compound 4 lay 34 percentage points above the measured number; measured number outside the range, below it.
By their numbers in this assay, from the lowest: compounds 3 and 4 (each within the scatter of the next); then compounds 2 and 1 (each within the scatter of the next).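

In this assay, going by these compounds alone, the step of a number 49 percentage points lower from compound 1 to compound 4 (beyond the scatter) shows that the carbonyl carbon is also sensitive to change, which the earlier steps, made at other places, could not show. Propoxycarbonyl to ethylcarbamoyl costs as much as the step of a number 49 percentage points lower from compound 1 to compound 3 (beyond the scatter), and the entering ethylamino brings a hydrogen-bond donor that propoxy lacks. Nothing available explains this result.

The compounds shown leave open whether the fall follows the nitrogen or the shorter chain. Propylamino or ethoxy on the same carbonyl carbon would separate the two.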